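A bulkier nitrogen substituent on compound 3

A few compounds are considered here, and "the series" means these few. Any claim that something is new, unique, unknown or untested is made for them only; others in the source may bear on it.

Compound 1 `COc1ccc2cc(-c3ccccc3)c(O)nc2c1`: 10000 nM
Compound 2 `COc1ccc(-c2cc3cccc(OC)c3nc2O)cc1`: 10000 nM
Compound 3 `COc1ccc(-c2cc3c(OC)cc(OC)cc3n(CC#N)c2=O)cc1`: 10000 nM

In a functional assay on A-427 cells (Homo sapiens) for cytotoxicity, read by colorimetric assay and MTT assay (a lower number here means a stronger inhibitor, a higher number a weaker inhibitor), compound 3 gives 10000 nM, level with compound 1 and compound 2 within the scatter. Compound 4 `COc1ccc(-c2cc3c(OC)cc(OC)cc3n(CCC(=O)OCc3ccccc3)c2=O)cc1` has not yet been measured. It carries (benzyloxycarbonyl)methyl in place of cyano on a saturated chain carbon bound to an aromatic nitrogen. Going by the values given here, no two measured compounds differ in one place, so no measured step serves as a guide. In this assay no change beyond the scatter is expected, with any shift more likely toward a lower number, since compound 3 stands at 10000 nM. The expected change is a 1.3-fold lower number from compound 3 to compound 4 (0.10 log units; within the scatter). For compound 4 the estimated value is 8000 nM, with an expected range from 2500 nM to 12000 nM.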

Compound 4, half-maximal inhibitory concentration: 10000 nM
Compound 4: the middle estimate sits 1.3-fold (0.10 log units) below what was measured; low and high end bracket the measured number.
By their numbers in this assay, from the lowest: compounds 1, 2, 3 and 4 (each within the scatter of the next).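

In this assay, going by these compounds alone, the one step that can be read at this place, (benzyloxycarbonyl)methyl in place of cyano on a saturated chain carbon bound to an aromatic nitrogen, gives no change at the digits printed from compound 3 to compound 4 (within the scatter) even though the entering group brings 11 heavy atoms and a six-membered aromatic ring of carbon only. So a much larger group on this chain leaves the number where it stood. Nothing at hand explains this outcome.

From the compounds shown here alone, whether a carboxylic acid or an amine at the end of this chain would move the value away from that of compound 3 stays open.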